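A few compounds are considered here, and "the series" means these few. Any claim that something is new, unique, unknown or untested is made for them only; others in the source may bear on it.

Measured so far:
compound 1 `O=C(Nc1cccc(-n2cc(-c3ccncc3)c(-c3cc(O)cc(Cl)c3)n2)c1)Nc1ccc(Cl)c(C(F)(F)F)c1` — 58%
compound 2 `O=C(Nc1cccc(-n2cc(-c3ccncc3)c(-c3cc(O)cc(Cl)c3)n2)c1)Nc1ccc(Cl)c(Cl)c1` — 38%

Among the compounds with values here, in a functional assay on RXF 393 cells (Homo sapiens) for inhibition, read by sulforhodamine B assay, with a stated time of 48 h, tested at 1 uM (on this read-out lower numbers stand for a stronger effect and higher numbers for a weaker effect at the one concentration tested), compound 1 stands highest of the two numbers, and the only measured step, a number 20 percentage points lower from compound 1 to compound 2 (beyond the scatter), lies beyond the scatter. Compound 3 `COc1cc(Cl)cc(-c2nn(-c3cccc(NC(=O)Nc4ccc(Cl)c(C(F)(F)F)c4)c3)cc2-c2ccncc2)c1` differs from compound 1 by methyl in place of hydrogen on an oxygen on an aromatic ring. Within the data shown here, that measured step concerns a different ring and does not bear on this change, and no measured pair covers hydroxy to methoxy. Hence no step beyond the scatter is expected: a number 2 percentage points higher from compound 1 to compound 3 (within the scatter). Compound 3 is therefore estimated at 60%, with a range of 40% to 80%.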

Compound 3, a percentage reported as activity, at one concentration (the size of the read-out at that concentration, not a potency): 78%
Beside the measured number, compound 3's estimate is 18 percentage points below it; low and high end bracket the measured number.
By their numbers in this assay, from the lowest: compound 2; then compound 1; then compound 3.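

In this assay, hydroxy to methoxy on the 3-chloro-5-hydroxyphenyl group gives a number 20 percentage points higher from compound 1 to compound 3 (beyond the scatter) and so a weaker effect at the one concentration tested. This shows that the series responds to a change at this oxygen, and not only to the chloro in place of trifluoromethyl change on the other ring, which gave a number 20 percentage points lower from compound 1 to compound 2 (beyond the scatter) in the opposite direction. Nothing available explains the step at this oxygen.

Still open, going by these compounds, is whether a free hydroxy is needed here, which an amine or a longer ethoxy chain at this place could test. Also open, on these data alone, is whether methoxy has the same effect on the core of compound 2.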